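The source may hold more compounds than are shown below. What is called first, only, known or untested is meant among the compounds shown, and "the series" means these compounds.

Measured so far:
compound 1 `Cc1[nH]n(-c2nc3cc(Cl)ccc3[nH]2)c(=O)c1Cc1ccccc1` — in an assay on isolated protein for inhibition of alpha-ketoglutarate-dependent dioxygenase alkB homolog 3 (Homo sapiens), read by polymerase chain reaction, with a stated time of 1 h (a higher number here means a weaker inhibitor, a lower number a stronger inhibitor), compound 1 gives 4500 nM
compound 2 `Cc1[nH]n(-c2nc3cc(C(C)(C)C)ccc3[nH]2)c(=O)c1Cc1ccccc1` — compound 2 gives 640 nM
compound 3 `Cc1ccc2[nH]c(-n3[nH]c(C)c(Cc4ccc(Cl)cc4)c3=O)nc2c1` — compound 3 gives 750 nM

Between compound 1 and compound 2 the change is tert-butyl in place of chloro on an aromatic carbon, and it brought a 7.0-fold lower number from compound 1 to compound 2 (0.85 log units; beyond the scatter). The cores of compound 1 and compound 3 differ, but that difference is not broken down here; their values show compound 3 well inside the range of compound 2.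

Compound 4 `Cc1ccc2[nH]c(-n3[nH]c(C)c(Cc4ccc(C(C)(C)C)cc4)c3=O)nc2c1` is not yet measured. It differs from compound 3 by tert-butyl in place of chloro on an aromatic carbon. This is the same kind of change as from compound 1 to compound 2, not the same: there the ring was part of a fused system, meta and para to a fused ring, here it is a six-membered ring of carbon only, para to a large group. A step of comparable size is expected, a 5.0-fold lower number from compound 3 to compound 4 (0.70 log units; beyond the scatter), resting on a 7.0-fold lower number from compound 1 to compound 2 (0.85 log units; beyond the scatter) seen once only. Compound 4 is therefore estimated at 150 nM, between 40 nM and 600 nM.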

Compound 4, half-maximal inhibitory concentration: 3700 nM
Compound 4: middle estimate off by 25-fold (1.39 log units), on the low side, outside the stated range (above it).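

Tert-butyl in place of chloro on an aromatic carbon of the six-membered aromatic ring of carbon only brought a 4.9-fold higher number from compound 3 to compound 4 (0.69 log units; beyond the scatter) in this assay. The same change therefore does not carry over in direction or size between these two cores, and a step measured on one gives no usable estimate for the other: the same change on two cores in this assay, a 7.0-fold lower number (0.85 log units; beyond the scatter) from compound 1 to compound 2 and a 4.9-fold higher number (0.69 log units; beyond the scatter) from compound 3 to compound 4, 35-fold (1.54 log units) apart, beyond the scatter of two such steps This rests on one pair per core, and the two pairs differ both in the ring carrying the change and in the rest of the structure, so what sets the direction is not shown.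

Still open, as far as these compounds go, is how other groups in place of chloro on this ring would behave, such as an amine, a carboxylic acid or a longer chain. Also open, from the compounds shown here alone, is whether a second pair on either core would repeat the step seen there.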